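Notes on the shared core: ethyl to chloro

The source may hold more compounds than are shown below. What is called first, only, known or untested is meant among the compounds shown, and "the series" means these compounds.

Measured so far:
compound 1, `Cc1cc(Cl)c(S(C)(=O)=O)cc1C(=O)N=C(N)N`, 25 nM
compound 2, `CCc1cc(Cl)c(S(C)(=O)=O)cc1C(=O)N=C(N)N`, 63 nM

Both compounds were tested in a functional assay for inhibition of sodium/hydrogen exchanger (Oryctolagus cuniculus); on this read-out higher numbers stand for weaker inhibition and lower numbers for stronger inhibition. Compound 2 stands at the highest of the two numbers; its nearest neighbour is compound 1, and the step of a 2.5-fold higher number from compound 1 to compound 2 (0.40 log units; beyond the scatter) is modest but beyond the scatter. Compound 3, `CS(=O)(=O)c1cc(C(=O)N=C(N)N)c(Cl)cc1Cl`, has not yet been measured. It differs from compound 2 by chloro in place of ethyl on an aromatic carbon. For the measured compounds named here, no measured step covers a chloro entering in place of an alkyl group at this carbon; the only step in hand, a 2.5-fold higher number from compound 1 to compound 2 (0.40 log units; beyond the scatter), shows that adding a methyl to the chain raised the number, so a return to a group of one heavy atom is expected to undo part of that change rather than all of it. The expected step is a 2.0-fold lower number from compound 2 to compound 3 (0.29 log units; within the scatter). Compound 3 is therefore estimated at 32 nM, with a range from 12 nM to 90 nM.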

Compound 3, half-maximal inhibitory concentration: 140 nM
Estimate against measurement, compound 3: 4.4-fold (0.64 log units) below; the measured number lies above the stated range.
By their numbers in this assay, from the lowest: compound 1; then compound 2; then compound 3.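

At this carbon, para to the methylsulfonyl group, chloro does not bring the number back towards that of the methyl analogue: in this assay, the change from ethyl to chloro gives a 2.2-fold higher number from compound 2 to compound 3 (0.35 log units; beyond the scatter), and the change from methyl to chloro gives a 5.6-fold higher number from compound 1 to compound 3 (0.75 log units; beyond the scatter). Among the three groups, the number therefore rises from methyl through ethyl to chloro, with every step beyond the scatter. Heavy-atom count does not set this order, since chloro with 1 heavy atom stands above ethyl with 2 heavy atoms.

Open questions are whether a methoxy group, an amine or plain hydrogen at this carbon would give a number lower than that of compound 1, and whether a longer chain such as propyl would continue the rise seen from methyl to ethyl. No measurement in hand bears on the reason for this order.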